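Ethoxy added to the bromophenyl of compound 3

The source may report more compounds than this note shows. Statements on the series, on what has been measured and on what is new or still open speak of the compounds shown alone.

compound 1 `Cc1cc(=O)c2c(O)cc(OCc3ccc(Br)cc3)c([C@H]3CCN(C)C[C@H]3O)c2o1` gives 14%
compound 2 `CCOC(=O)N1CCN(Cc2c(O)c([C@H]3CCN(C)C[C@H]3O)c3oc(C)cc(=O)c3c2O)CC1` gives 31%
compound 3 `Cc1oc2c([C@H]3CCN(C)C[C@H]3O)c(O)cc(O)c2c(=O)c1C(O)c1ccccc1Br` gives 21%

These values come from a functional assay on MCF7 cells (Homo sapiens) for inhibition, read by MTT assay, with a stated time of 48 h, tested at 10 uM (a lower number here means less inhibition of growth, a higher number more inhibition of growth at the concentration tested), and compound 3 lies within the scatter of both compound 1 and compound 2. Compound 4 (`CCOc1ccc(Br)c(C(O)c2c(C)oc3c([C@H]4CCN(C)C[C@H]4O)c(O)cc(O)c3c2=O)c1`) keeps the core of compound 3 and turns its 2-bromophenyl into 2-bromo-5-ethoxyphenyl, with ethoxy in place of hydrogen on an aromatic carbon, para to a bromo group (ethoxy in place of hydrogen on an aromatic carbon). Going by the values given here, no measured pair here shows what such a change does, so the expectation rests on compound 3 at 21% as the closest relative. No shift beyond the scatter is expected in this assay and no direction is favoured. The expected step (a number 1 percentage points higher from compound 3 to compound 4 (within the scatter)) is therefore small. Compound 4 is expected at 22% with an estimated range from 8% to 38% when it is measured.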

Compound 4, percent growth inhibition at one concentration: 9%
Beside the measured number, compound 4's estimate is 13 percentage points above it, and the stated range covers the measured number.
By their numbers in this assay, from the lowest: compounds 4, 1, 3 and 2 (each within the scatter of the next, the first and the last beyond it).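

In this assay, ethoxy in place of hydrogen on an aromatic carbon, para to a bromo group, gives a number 12 percentage points lower from compound 3 to compound 4 (beyond the scatter). Going by these compounds alone, this is the first single-place change, and it shows that this carbon of the bromophenyl does not accept the added ethoxy without a loss of growth inhibition. Nothing at hand accounts for the drop.

Going by these compounds, whether a methoxy, a hydroxyl or an amine on the same carbon would lower the number as well remains open. So does whether the drop depends on the bromo group.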